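Extending the Piperidine Amide with a Hydroxyethyl Group

A few compounds are considered here, and "the series" means these few. Any claim that something is new, unique, unknown or untested is made for them only; others in the source may bear on it.

Compound 2 `COc1cc(C(=O)N2CC[C@H](O)[C@@H](C)C2)cc2nc(NCc3cccc(Cl)c3)oc12` belongs to a small set of close relatives that share one core and differ only in the ring attached to the carbonyl carbon. In an assay on isolated protein for inhibition of thyroid hormone receptor beta (Homo sapiens), read by fluorescence, with a stated time of 30 min (a higher number here means a weaker inhibitor, a lower number a stronger inhibitor), compound 2 gives 120 nM, the highest of the two single numbers available. Its nearest neighbour, compound 1 `COc1cc(C(=O)N2CCCC2(C)C)cc2nc(NCc3cccc(Cl)c3)oc12`, gives 47 nM, and the step of a 2.6-fold higher number from compound 1 to compound 2 (0.41 log units; beyond the scatter) is modest but beyond the usual scatter. Compound 3 `COc1cc(C(=O)N2CC(C)C(O)CC2C)cc2nc(NCc3cccc(Cl)c3)oc12` has several entries, giving 66 nM; 45 nM (2 entries), so no single number stands for it (the several entries of compound 3 in this assay, 66 nM; 45 nM (2 entries)).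

Compound 4 `COc1cc(C(=O)N2CC(C)C(O)CC2CCO)cc2nc(NCc3cccc(Cl)c3)oc12` has not yet been measured. It differs from compound 2 by 4-hydroxy-2-(2-hydroxyethyl)-5-methylpiperidin-1-yl in place of 4-hydroxy-3-methylpiperidin-1-yl on a carbonyl carbon. Among the measured compounds shown here, no measured step covers this exact change. For the measured compounds named here, the only related evidence comes from compound 3, whose amide ring is also more heavily substituted than that of compound 2 and whose entries lie near the number of compound 1. This suggests that further substitution on the amide ring is tolerated, though nothing here tests a hydroxyethyl group itself.

In this assay compound 4 is therefore expected to give about 100 nM, with a likely range from 40 nM to 300 nM. The expected step of a 1.2-fold lower number from compound 2 to compound 4 (0.08 log units; within the scatter) is small and within the scatter, in no clear direction.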

Compound 4, half-maximal inhibitory concentration: 0.27 nM
The estimate for compound 4 lay 370-fold (2.57 log units) above the measured number; measured number outside the range, below it.
By their numbers in this assay, from the lowest: compound 4; then compound 1; then compound 2.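

Among the compounds shown here, the ring on the carbonyl carbon turns out to matter far more than the earlier compounds suggested: in this assay, 4-hydroxy-2-(2-hydroxyethyl)-5-methylpiperidin-1-yl gives a 440-fold lower number from compound 2 to compound 4 (2.65 log units; beyond the scatter), and the same group in place of 2,2-dimethylpyrrolidin-1-yl gives a 170-fold lower number from compound 1 to compound 4 (2.24 log units; beyond the scatter). Until now, changing this ring had moved the number only modestly, so steps of this size are new. Compound 3, whose ring lacks the 2-hydroxyethyl group and carries a methyl instead, stays far above compound 4, which points to the 2-hydroxyethyl group itself rather than to extra substitution on the ring in general, as its printed numbers show: the several entries of compound 3 in this assay, 66 nM; 45 nM (2 entries)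

The compounds shown leave open whether the hydroxyl of the 2-hydroxyethyl group matters or the chain alone is enough, a question that a plain ethyl group could settle. They also do not show how an amine or a carboxylic acid at the end of that chain, or a longer chain, would compare.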